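The source may hold more compounds than are shown below. What is called first, only, known or untested is meant among the compounds shown, and "the series" means these compounds.

Compound 1 `CN1C[C@@H](c2ccc(F)cc2)[C@@]2(Cc3ccccc3C2=O)[C@@]12C(=O)Nc1ccccc12`: 40.6%
Compound 2 `CN1C[C@@H](c2ccc(Cl)cc2)[C@@]2(Cc3ccccc3C2=O)[C@@]12C(=O)Nc1ccccc12`: 27.9%

In a functional assay on the whole organism (strain Wister albino) for inhibition, with Rattus norvegicus as the target, read by paw edema, with a stated time of 1 h, at a dose of 50 mg/kg by the intraperitoneal route (a lower number here means less inhibition, a higher number more inhibition at the dose given (going by the name of the read-out)), compound 2 gives 27.9%, the lower of the two measured numbers, while compound 1 gives 40.6%. Among the measured compounds shown here, the only measured step is a number 12.7 percentage points lower from compound 1 to compound 2 (beyond the scatter). Compound 3 `COc1ccc([C@@H]2CN(C)[C@]3(C(=O)Nc4ccccc43)[C@]23Cc2ccccc2C3=O)cc1` is not yet measured. Compared with compound 2 it carries methoxy in place of chloro on an aromatic carbon. For the measured compounds named here, no measured step exchanges a halogen for methoxy, so the one known step is a weak guide here. The expected step for compound 3 is therefore small, a number 5.1 percentage points higher from compound 2 to compound 3 (within the scatter), with a wide range. Compound 3 is estimated at 33%, between 18% and 48%.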

Compound 3, a percentage reported as inhibition, in the whole organism at one dose (the size of the read-out at that dose, not a potency): 41.2%
Compound 3: the middle estimate sits 8.2 percentage points below what was measured; the measured number falls inside the stated range.
By their numbers in this assay, from the lowest: compound 2; then compounds 1 and 3 (each within the scatter of the next).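

In this assay, swapping chloro for methoxy on the aromatic ring, para to a large group, gives a number 13.3 percentage points higher from compound 2 to compound 3 (beyond the scatter). Swapping fluoro for methoxy at the same place gives a number 0.6 percentage points higher from compound 1 to compound 3 (within the scatter), so methoxy and fluoro cannot be told apart here, and the chloro compound alone stands lower among these three. Nothing available explains why chloro differs from the other two groups. Still open, on these data alone, is whether an amine or a carboxylic acid at this place would give a number like that of the chloro compound or like those of the other two.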